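The source may report more compounds than this note shows. Statements on the series, on what has been measured and on what is new or still open speak of the compounds shown alone.

Measured compounds: compound 1 `CCCCOc1ccc(-c2nc3ncccn3c2NCC2CCCCC2)cc1` and compound 2 `CCCCOc1ccc(-c2nc3ncccn3c2NCc2ccccn2)cc1`.

In a toxicity assay on A549 cells (Homo sapiens) for cytotoxicity, read by luminescence and CellTiter-Glo, with a stated time of 48 h (on this read-out lower numbers stand for higher toxicity in this test and higher numbers for lower toxicity in this test), compound 1 gives 35000 nM. Compound 2 reaches only a limit of the assay in this assay, namely > 100000 nM. The step of an at least 2.8-fold higher number from compound 1 to compound 2 (0.45 log units; beyond the scatter) is thus bounded on one side only, and compound 2 sits at the limit of > 100000 nM in this assay, at which 1 of the 2 values shown sits, the less toxic end of what has been measured. Compound 3 `CCCCOc1ccc(-c2nc3ncccn3c2NCc2ccc(OC)cc2)cc1` has not yet been measured; it differs from compound 2 by 4-methoxyphenyl in place of pyridin-2-yl on a saturated chain carbon bound to a nitrogen on an aromatic ring. Among the measured compounds shown here, no measured step changes pyridin-2-yl into 4-methoxyphenyl, and the single step known, from compound 1 to compound 2, concerns a different exchange at this carbon and gives only a bound. The expectation for compound 3 in this assay is therefore a step of an at least 1.4-fold lower number from compound 2 to compound 3 (0.15 log units; that floor lies within the scatter) that need not exceed the scatter in either direction. Compound 3 is estimated at 70000 nM, between 25000 nM and 150000 nM.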

Compound 3, half-maximal cytotoxic concentration: 55000 nM
Beside the measured number, compound 3's estimate is 1.3-fold (0.10 log units) above it, within the range that was stated.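

In this assay, an aromatic ring on this saturated chain carbon does not by itself bring a compound to the limit of the assay, since 4-methoxyphenyl in place of cyclohexyl gives a 1.6-fold higher number from compound 1 to compound 3 (0.20 log units; within the scatter), and these two groups cannot be told apart here. Exchanging pyridin-2-yl for 4-methoxyphenyl gives an at least 1.8-fold lower number from compound 2 to compound 3 (0.25 log units; that floor lies within the scatter), so this change is not shown to exceed the scatter, although its true size may be larger. Compound 2 stands at a limit of the assay, so this step is bounded on one side only: the limit of > 100000 nM in this assay, at which 1 of the 3 values shown sits.

A plain phenyl group at this carbon would be needed to separate the part played by the ring nitrogen of pyridin-2-yl from that of the methoxy group of 4-methoxyphenyl. Going by these compounds, whether an amine, a carboxylic acid or a longer chain here would move the number beyond the scatter remains open.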